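Amide nitrogen substituent: ethyl to cyclohexyl in the thiourea series

This account rests on a few compounds, and the source may have more. Where it says the series, first, only, none or still open, it means among the compounds named here.

Working notes on three measured compounds and one awaiting measurement. Compound 1 `CNC(=O)c1cc(Oc2cccc(NC(=S)Nc3ccc(Cl)cc3)c2)ccn1` gives 24100 nM in a functional assay on PC-3 cells (Homo sapiens) for cytotoxicity, read by MTT assay, with a stated time of 48 h; on this read-out higher numbers stand for weaker inhibition and lower numbers for stronger inhibition; compound 2 `CNC(=O)c1cc(Oc2cccc(NC(=S)Nc3ccc(F)c(F)c3)c2)ccn1` gives 33100 nM; compound 3 `CCNC(=O)c1cc(Oc2cccc(NC(=S)Nc3ccc(F)c(F)c3)c2)ccn1` gives 26300 nM. The three numbers sit close together, and compound 3 stands second highest of them, with its gaps to compound 1 and compound 2 both within the scatter. Compound 4 `O=C(NC1CCCCC1)c1cc(Oc2cccc(NC(=S)Nc3ccc(F)c(F)c3)c2)ccn1` carries a (cyclohexyl in place of ethyl on an amide-type nitrogen). Among the compounds with values here, the one step touching the same place, a 1.3-fold lower number from compound 2 to compound 3 (0.10 log units; within the scatter), stayed within the scatter, while a 1.4-fold higher number from compound 1 to compound 2 (0.14 log units; within the scatter) concerns another part of the molecule. Within the data shown here, no measured step covers a change of this size, so no step beyond the scatter is expected, a 1.2-fold lower number from compound 3 to compound 4 (0.08 log units; within the scatter). Compound 4 is estimated at 22000 nM, between 9000 nM and 55000 nM.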

Compound 4, half-maximal inhibitory concentration: 8100 nM
The estimate for compound 4 lay 2.7-fold (0.43 log units) above the measured number, outside the stated range (below it).
By their numbers in this assay, from the lowest: compound 4; then compounds 1, 3 and 2 (each within the scatter of the next).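

Within the data shown here, on the amide-type nitrogen, cyclohexyl is the first group to move the number in this assay beyond the scatter, with a 3.2-fold lower number from compound 3 to compound 4 (0.51 log units; beyond the scatter) and a 4.1-fold lower number from compound 2 to compound 4 (0.61 log units; beyond the scatter), so this position is not as flat as the methyl and ethyl compounds suggested. Nothing available here accounts for this shift.

Whether it follows the ring or simply the larger carbon count stays open, since the compounds shown include neither cyclopentyl, phenyl nor a longer open chain such as hexyl on this nitrogen. Cyclohexyl also appears only with the 3,4-difluorophenyl group, so its effect alongside 4-chlorophenyl remains unknown.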